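The source may report more compounds than this note shows. Statements on the series, on what has been measured and on what is new or still open speak of the compounds shown alone.

Compound 3 `CNc1nc(C#Cc2ccc(Cl)s2)nc2c1ncn2[C@H]1[C@H](O)[C@H](O)[C@]2(C(=O)OCCC(C)C)C[C@H]12` gives the highest of the three numbers in an assay on cells for displacement of a labelled ligand from adenosine receptor A3 (Mus musculus), read by scintillation counting and radioligand binding, with stated times of 10 min and 90 min, tested at 10 uM (on this read-out lower numbers stand for less inhibition and higher numbers for more inhibition at the one concentration tested (going by the name of the read-out)), namely 32%. Compound 2 `CNc1nc(C#Cc2ccc(Cl)s2)nc2c1ncn2[C@H]1[C@H](O)[C@H](O)[C@]2(C(=O)OC(C)C)C[C@H]12` gives 30% in this assay, and compound 1 `CCOC(=O)[C@@]12C[C@@H]1[C@@H](n1cnc3c(NC)nc(C#Cc4ccc(Cl)s4)cc31)[C@H](O)[C@@H]2O` gives 18%. For the measured compounds named here, the one measured step on an oxygen next to a carbonyl group, a number 2 percentage points higher from compound 2 to compound 3 (within the scatter), involved isopentyl in place of isopropyl. Compound 4 `CNc1nc(C#Cc2ccc(Cl)s2)nc2c1ncn2[C@H]1[C@H](O)[C@H](O)[C@]2(C(=O)OCc3ccccc3)C[C@H]12` differs from compound 3 by phenyl in place of isobutyl on a saturated chain carbon bound to an oxygen next to a carbonyl group. Going by the values given here, no measured step brings a six-membered aromatic ring to this place, and the only step there, a number 2 percentage points higher from compound 2 to compound 3 (within the scatter), was within the scatter. Compound 4 is therefore expected to show no step beyond the scatter, no change at the digits printed from compound 3 to compound 4 (within the scatter). Compound 4 is estimated at 32% in this assay, with a range from 15% to 50%.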

Compound 4, a percentage reported as inhibition, at one concentration (the size of the read-out at that concentration, not a potency): 48%
Compound 4: middle estimate off by 16 percentage points, on the low side; the measured number falls inside the stated range.
By their numbers in this assay, from the lowest: compound 1; then compounds 2 and 3 (each within the scatter of the next); then compound 4.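

Up to now, the only step on an oxygen next to a carbonyl group stayed within the scatter, so this place seemed to make little difference. In this assay that no longer holds: phenyl in place of isobutyl gives a number 16 percentage points higher from compound 3 to compound 4 (beyond the scatter) and benzyl in place of isopropyl gives a number 18 percentage points higher from compound 2 to compound 4 (beyond the scatter) at this same place. No measurement at hand explains this rise. Still open, from the compounds shown here alone, is whether phenethyl or pyridylmethyl in place of benzyl would keep the higher number, and what a free carboxylic acid would give here.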